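Amino for methyl on the benzylic carbon: cytotoxicity outlook

The source may report more compounds than this note shows. Statements on the series, on what has been measured and on what is new or still open speak of the compounds shown alone.

The set shares one core and is varied only on a saturated chain carbon bound to an aromatic carbon. Compound 1 `CCc1cccc2c1nc(-c1c(F)cccc1F)n2Cc1c(F)cccc1F` carries methyl there; in a toxicity assay on CCRF-CEM cells (Homo sapiens) for cytotoxicity (on this read-out lower numbers stand for higher toxicity in this test and higher numbers for lower toxicity in this test), compound 1 gives 26.1 uM. Compound 2 `CC(C)=CCc1cccc2c1nc(-c1c(F)cccc1F)n2Cc1c(F)cccc1F` gives 28.3 uM in this assay, and the step of a 1.1-fold higher number from compound 1 to compound 2 (0.04 log units; within the scatter). Compound 3 `[N-]=[N+]=NCc1cccc2c1nc(-c1c(F)cccc1F)n2Cc1c(F)cccc1F` reaches only the assay limit in this assay, recorded as > 100 uM. From compound 1 the step reads an at least 3.8-fold higher number from compound 1 to compound 3 (0.58 log units; beyond the scatter), and from compound 2 an at least 3.5-fold higher number from compound 2 to compound 3 (0.54 log units; beyond the scatter). Among the numbers shown, compound 1 stands lowest of the two, with compound 2 within the scatter of it; the third value is a limit.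

Compound 4 `NCc1cccc2c1nc(-c1c(F)cccc1F)n2Cc1c(F)cccc1F` differs from compound 1 by amino in place of methyl on a saturated chain carbon bound to an aromatic carbon. Of the measured steps, a 1.1-fold higher number from compound 1 to compound 2 (0.04 log units; within the scatter) shows that a different carbon chain at this place changes little, whereas an at least 3.8-fold higher number from compound 1 to compound 3 (0.58 log units; beyond the scatter) shows that a nitrogen group entering at the same place moves the number beyond the scatter, up to the limit (the limit of > 100 uM in this assay, at which 1 of the 3 values shown sits). The amino change is nearer to the azido change than to the carbon-chain change, so a modest rise is expected. The step expected for compound 4 is a 2.3-fold higher number from compound 1 to compound 4 (0.36 log units; beyond the scatter). Compound 4 is estimated at 60 uM, with a range from 25 uM to 150 uM, and a fair chance that only a limit is recorded.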

Compound 4, half-maximal toxic concentration: 49.3 uM
Estimate against measurement, compound 4: 1.2-fold (0.09 log units) above; measured number inside the range.
By their numbers in this assay, from the lowest: compounds 1, 2 and 4 (each within the scatter of the next). At a limit, above all of these: compound 3.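

Amino in place of methyl gives a 1.9-fold higher number from compound 1 to compound 4 (0.28 log units; within the scatter), and against the other carbon group it gives a 1.7-fold higher number from compound 2 to compound 4 (0.24 log units; within the scatter), so a nitrogen group at this saturated chain carbon does not by itself move the number beyond the scatter. Azido in place of amino gives the reverse reading, an at least 2.0-fold lower number from compound 3 to compound 4 (0.30 log units; that floor lies within the scatter), so this pair shows no separation beyond the scatter, and the steps beyond it still stand only from compounds 1 and 2 to compound 3. Compound 3 is recorded only as a limit: the limit of > 100 uM in this assay, at which 1 of the 4 values shown sits.

From the compounds shown here alone, how far compound 3 truly lies from compound 4 stays open. Also open, going by these compounds, is whether a dimethylamino group, a longer aminoalkyl chain or a carboxylic acid at this place would stay within the scatter of compound 1.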